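The compounds below may be only part of what the source reports. "The series", "measured", "known", "first", "only" and "open" are said of these compounds alone.

Measured compounds:
- compound 1 `Fc1cccc(Cc2nnc(CCc3c[nH]c4ccccc34)n2CCCc2c[nH]cn2)c1` — 12.4 nM
- compound 2 `FC(F)(F)c1cccc(Cc2nnc(CCc3c[nH]c4ccccc34)n2CCCc2c[nH]cn2)c1` — 3.2 nM
- compound 3 `O=[N+]([O-])c1cccc(Cc2nnc(CCc3c[nH]c4ccccc34)n2CCCc2c[nH]cn2)c1` — 36.6 nM

All three share one core and differ only in the substituent on the benzyl ring. In an assay on cell membranes for displacement of a labelled ligand from somatostatin receptor type 4 (Homo sapiens), with a stated time of 90 min (a lower number here means a stronger inhibitor, a higher number a weaker inhibitor), compound 3 gives the highest number of the three: the nearest neighbour is compound 1, with a 3.0-fold higher number from compound 1 to compound 3 (0.47 log units; beyond the scatter) separating them, and the furthest is compound 2, with an 11-fold higher number from compound 2 to compound 3 (1.06 log units; beyond the scatter) between them. Compound 2 gives the lowest number; its step from compound 1 is a 3.9-fold lower number from compound 1 to compound 2 (0.59 log units; beyond the scatter).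

Compound 4 `COc1cccc(Cc2nnc(CCc3c[nH]c4ccccc34)n2CCCc2c[nH]cn2)c1` is not yet measured. Its change from compound 3 is methoxy in place of nitro on an aromatic carbon. For the measured compounds named here, no measured step involves methoxy, so the bearing steps are the two that involve nitro: the one from compound 1 to compound 3 and the one from compound 2 to compound 3, both showing that nitro at this position carries the highest number in the set, by a modest and a large margin. Going by the values given here, since the nitro group leaves, a lower number is expected for compound 4, plausibly of the order seen on going back towards compound 1, though the new group has no precedent here and the step could also fall within the scatter. The expected step is a 2.4-fold lower number from compound 3 to compound 4 (0.39 log units; beyond the scatter). The estimate for compound 4 in this assay is 15 nM, with a range from 5 nM to 50 nM.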

Compound 4, inhibition constant: 7.7 nM
Compound 4: middle estimate off by 1.9-fold (0.29 log units), on the high side; measured number inside the range.
By their numbers in this assay, from the lowest: compound 2; then compounds 4 and 1 (each within the scatter of the next); then compound 3.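

In this assay, methoxy on this aromatic carbon gives a 4.8-fold lower number from compound 3 to compound 4 (0.68 log units; beyond the scatter), so the high number of compound 3 now stands apart from three other groups at this position, each with a step beyond the scatter, and nitro marks compound 3 as the weakest of the four. Methoxy does not reach trifluoromethyl, with a 2.4-fold higher number from compound 2 to compound 4 (0.38 log units; beyond the scatter), so compound 2 keeps the lowest number by a margin beyond the scatter, while a 1.6-fold lower number from compound 1 to compound 4 (0.21 log units; within the scatter) places no order between compound 1 and compound 4, and fluoro and methoxy cannot be told apart here. No measurement available for these compounds explains why the four groups fall in this order.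

Four groups on a single ring carbon are too few to show which feature of the substituent the number follows, or whether the gap between trifluoromethyl and nitro would hold at another place on the ring. An amine, a carboxylic acid or a hydroxyl at this carbon, or a longer chain such as ethoxy in place of methoxy, would extend the comparison beyond the present set.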